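Restoring an Aromatic Ring at the Saturated Carbon

The source may report more compounds than this note shows. Statements on the series, on what has been measured and on what is new or still open speak of the compounds shown alone.

Of the compounds shown here, three sharing one core have been tested in a functional assay on Ehrlich cells (Mus musculus) for antiproliferative activity, read by trypan blue exclusion, with a stated time of 2 h, tested at 100 ug/mL; on this read-out lower numbers stand for a weaker effect and higher numbers for a stronger effect at the one concentration tested. Compound 1 `Cc1ccc(C2C(C#N)=C(N)N(c3ccc(S(N)(=O)=O)cc3)C3=C2C(=O)CCC3)cc1` gives 100%. Compound 2 `N#CC1=C(N)N(c2ccc(S(N)(=O)=O)cc2)C2=C(C(=O)CCC2)C1c1ccc(O)cc1` differs by a hydroxy in place of methyl on an aromatic carbon; in this assay compound 2 gives 100%, and no change at the digits printed from compound 1 to compound 2 (within the scatter). Compound 3 `N#CC1=C(N)N(c2ccc(S(N)(=O)=O)cc2)C2=C(C(=O)CCC2)C1/C=C/c1ccccc1` gives 45%, the lowest of the three numbers; a number 55 percentage points lower from compound 1 to compound 3 (beyond the scatter) and a number 55 percentage points lower from compound 2 to compound 3 (beyond the scatter).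

Compound 4 `N#CC1=C(N)N(c2ccc(S(N)(=O)=O)cc2)C2=C(C(=O)CCC2)C1c1cccc([N+](=O)[O-])c1` is the next step from compound 3: 3-nitrophenyl in place of 2-phenylethenyl on a saturated ring carbon. Both large steps measured so far concern this same saturated ring carbon, where 2-phenylethenyl replaced an aromatic ring and the activity fell sharply. Compound 4 puts an aromatic ring back in that place, so the move is expected to run the other way, with an estimated step of a number 40 percentage points higher from compound 3 to compound 4 (beyond the scatter) that is large. For compound 4 the estimate in this assay is 85%, expected to lie between 45% and 100%.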

Compound 4, a percentage reported as activity, at one concentration (the size of the read-out at that concentration, not a potency): 71%
Compound 4: the middle estimate sits 14 percentage points above what was measured; low and high end bracket the measured number.
By their numbers in this assay, from the lowest: compound 3; then compound 4; then compounds 1 and 2 (each within the scatter of the next).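

Putting an aromatic ring back at the saturated ring carbon in this assay gives a number 26 percentage points higher from compound 3 to compound 4 (beyond the scatter) but does not by itself restore the read-out seen with the other two aromatic rings. The groups on that ring can therefore matter, something the exchange of methyl for hydroxy did not reveal: 3-nitrophenyl gives a number 29 percentage points lower from compound 1 to compound 4 (beyond the scatter) and also a number 29 percentage points lower from compound 2 to compound 4 (beyond the scatter) when set against 4-hydroxyphenyl. No accompanying measurement offers an explanation for these differences.

Since 3-nitrophenyl differs from 4-methylphenyl and 4-hydroxyphenyl both in the group and in its numbered place on the ring, the compounds shown cannot separate those two changes. Also open, going by these compounds, is how an amine or a carboxylic acid on this aromatic ring would read.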